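Chalcone-linked pyrazoles: cytotoxicity at a single low concentration

The compounds below may be only part of what the source reports. "The series", "measured", "known", "first", "only" and "open" are said of these compounds alone.

Compound 1 `COc1cc(-c2cc(/C=C/C(=O)c3ccc(N)cc3)[nH]n2)cc(OC)c1OC` and compound 2 `COc1ccc(-c2cc(/C=C/C(=O)c3ccc(OC)c(OC)c3)[nH]n2)cc1` were both tested in a functional assay on HCT-116 cells (Homo sapiens) for cytotoxicity, read by sulforhodamine B assay, with a stated time of 48 h, tested at 0.01 uM; on this read-out higher numbers stand for a weaker effect at the one concentration tested and lower numbers for a stronger effect. In this assay compound 1 gives 95%, and compound 2 gives 97%. Going by the values given here, compound 1 holds the lowest of the two numbers, but its nearest neighbour, compound 2, is only a little higher and within the scatter, so the two values are read as the same: at the single low concentration neither compound produces more than a marginal effect.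

Compound 3 `COc1cc(-c2cc(/C=C/C(=O)c3ccc(Cl)c(Cl)c3)[nH]n2)cc(OC)c1OC` is not yet measured. It differs from compound 1 by 3,4-dichlorophenyl in place of 4-aminophenyl on a carbonyl carbon. Among the compounds with values here, no measured pair in the set shares this change, so the expected step rests on the two values alone. Because compound 1 gives 95%, a result near the top of the scale is expected again, and the step of a number 1 percentage points lower from compound 1 to compound 3 (within the scatter) is expected to stay within the scatter, in no particular direction. For compound 3 the estimate is 94%, with a range from 82% to 104%.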

Compound 3, a percentage reported as activity, at one concentration (the size of the read-out at that concentration, not a potency): 102%
Compound 3: middle estimate off by 8 percentage points, on the low side; the range from low to high includes it.
By their numbers in this assay, from the lowest: compounds 1, 2 and 3 (each within the scatter of the next).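

In this assay, 3,4-dichlorophenyl in place of 4-aminophenyl on a carbonyl carbon gives a number 7 percentage points higher from compound 1 to compound 3 (within the scatter), so this position tolerates two quite different aryl groups without a readable difference at this concentration. An aryl group with a hydrogen-bond donor and acceptor and one carrying chlorine with neither give the same reading, and compound 3, at 102%, shows no marginal effect either. Nothing measured on these compounds offers an explanation for this result.

From the compounds shown here alone, whether a carboxylic acid, a morpholine or a longer chain on this carbonyl carbon would move the read-out beyond the scatter remains open. Going by these compounds, with values this close to the top of the scale at one low concentration, any difference between 4-aminophenyl and 3,4-dichlorophenyl at higher concentrations also remains open.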